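The source may report more compounds than this note shows. Statements on the series, on what has been measured and on what is new or still open speak of the compounds shown alone.

In a functional assay on MCF7 cells (Homo sapiens) for antiproliferative activity, read by MTT assay, with a stated time of 24 h (on this read-out higher numbers stand for weaker inhibition and lower numbers for stronger inhibition), three compounds sharing one core have been measured. Compound 1 `CCn1c(C(=O)N[C@@H](C)C(=O)OC)ccc1C(CC)(CC)c1ccc(OCS(=O)(=O)c2ccccc2)c(C)c1` gives 43700 nM, compound 2 `CCn1c(C(=O)N[C@@H](CO)CCO)ccc1C(CC)(CC)c1ccc(OCS(=O)(=O)c2ccccc2)c(C)c1` gives 27400 nM and compound 3 `CCn1c(C(=O)N[C@@H](C(=O)O)C(C)C)ccc1C(CC)(CC)c1ccc(OCS(=O)(=O)c2ccccc2)c(C)c1` gives 44700 nM, which places compound 3 within the scatter of both others. Compound 4 `CCn1c(C(=O)N[C@H](CC(=O)O)C(=O)O)ccc1C(CC)(CC)c1ccc(OCS(=O)(=O)c2ccccc2)c(C)c1` differs from compound 3 by carboxymethyl in place of isopropyl on a saturated chain carbon bound to an amide-type nitrogen and a carbonyl carbon: carboxymethyl in place of isopropyl, turning 1-carboxy-2-methylpropyl into 1,2-dicarboxyethyl. The closest evidence is the set of changes on the amide-type nitrogen: a 1.0-fold higher number from compound 1 to compound 3 (0.01 log units; within the scatter), a 1.6-fold higher number from compound 2 to compound 3 (0.21 log units; within the scatter) and a 1.6-fold lower number from compound 1 to compound 2 (0.20 log units; within the scatter), all within the scatter. With steps of that size, no change beyond the scatter is expected in this assay. The expected step is a 1.1-fold lower number from compound 3 to compound 4 (0.05 log units; within the scatter). Compound 4 is estimated at 40000 nM, with a range from 17000 nM to 90000 nM.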

Compound 4, half-maximal inhibitory concentration: > 50000 nM
Compound 4 ended at the assay's limit; the forecaster's own chance of this, stated with the estimate: 15%; middle value at least 1.2-fold (0.09 log units) away from the limit.
By their numbers in this assay, from the lowest: compounds 2, 1 and 3 (each within the scatter of the next). At a limit, above all of these: compound 4.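

In this assay, compound 4 is the only one of the four shown to give a limit and not a number: the limit of > 50000 nM in this assay, at which 1 of the 4 values shown sits.

The steps of an at least 1.1-fold higher number from compound 3 to compound 4 (0.04 log units; that floor lies within the scatter), an at least 1.8-fold higher number from compound 2 to compound 4 (0.26 log units; that floor lies within the scatter) and an at least 1.1-fold higher number from compound 1 to compound 4 (0.05 log units; that floor lies within the scatter) are floors only, and each floor lies within the scatter. Carboxymethyl in place of isopropyl on this carbon therefore moves the series out of the readable range, but by how much stays unknown.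

The compounds shown leave open how an amine such as aminomethyl, or a longer chain ending in a carboxylic acid, would read at this place.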